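Swapping a fluoro-methoxybenzyl for a furanylmethyl group

This account rests on a few compounds, and the source may have more. Where it says the series, first, only, none or still open, it means among the compounds named here.

Of the compounds shown here, three built on a shared core have been tested in an ADME assay on HepG2 cells (Homo sapiens) for cytotoxicity, read by luminescence, CellTiter-Glo and ATP content, with a stated time of 72 h; on this read-out lower numbers stand for an effect already at smaller amounts and higher numbers for an effect only at larger amounts of compound. Compound 1 `Fc1ccc(-c2ccc3c(NCCCNCc4ccco4)ccnc3c2)cc1` gives 7760 nM. Within the data shown here, compound 2 `CC(C)Cc1ccc2c(NCCCNCc3ccco3)ccnc2c1` gives 16000 nM, and the only single-point step among the measured compounds, a 2.1-fold higher number from compound 1 to compound 2 (0.31 log units; beyond the scatter), is a change on the aromatic part of the core. Compound 3 `COc1cccc(Oc2ccc3c(NCCCNCc4cc(F)ccc4OC)ccnc3c2)c1` gives 7100 nM, a number that lies within the usual scatter of compound 1 and sits below that of compound 2 by more than the scatter.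

Compound 4 `COc1cccc(Oc2ccc3c(NCCCNCc4ccco4)ccnc3c2)c1` is made from compound 3 by one change: furan-2-yl in place of 5-fluoro-2-methoxyphenyl on a saturated chain carbon bound to an amine nitrogen. The measured step from compound 1 to compound 2 touches a different part of the molecule, so it does not bear directly on this change. What does bear on it is that compound 1 and compound 2 both carry the (furan-2-yl)methyl group that enters in compound 4, and their numbers sit within, or only modestly beyond, the scatter of compound 3. The expected step from compound 3 to compound 4 in this assay is therefore a 1.2-fold higher number from compound 3 to compound 4 (0.08 log units; within the scatter), meaning no change beyond the scatter. Compound 4 is estimated to give about 8500 nM, with a likely range from 3500 nM to 20000 nM.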

Compound 4, half-maximal effective concentration: 15500 nM
Compound 4: the middle estimate sits 1.8-fold (0.26 log units) below what was measured; measured number inside the range.
By their numbers in this assay, from the lowest: compounds 3, 1, 4 and 2 (each within the scatter of the next, the first and the last beyond it).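

In this assay, the group on a saturated chain carbon bound to an amine nitrogen does affect the number: 5-fluoro-2-methoxyphenyl gives way to furan-2-yl in a modest step beyond the scatter (a 2.2-fold higher number from compound 3 to compound 4 (0.34 log units; beyond the scatter)). With furan-2-yl in place, 3-methoxyphenoxy on an aromatic carbon cannot be told apart from either isobutyl (a 1.0-fold lower number from compound 2 to compound 4 (0.01 log units; within the scatter)) or 4-fluorophenyl (a 2.0-fold higher number from compound 1 to compound 4 (0.30 log units; within the scatter)), even though those two groups differ from each other by slightly more than the scatter. Nothing available explains why the swap at the chain carbon moves the number.

Among these compounds, the swap has been seen only with 3-methoxyphenoxy on the core, so the same change alongside isobutyl or 4-fluorophenyl could give a step of another size. Going by these compounds, it also remains open whether the fluorine, the methoxy or the benzene ring itself matters, which a plain benzyl or a cyclohexylmethyl group on the same amine nitrogen would help to separate.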